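The source may report more compounds than this note shows. Statements on the series, on what has been measured and on what is new or still open speak of the compounds shown alone.

Among the measured compounds shown here, compound 3 `C=C(Br)C(=O)Nc1cccc(-c2cn3nc(-c4ccc(CC)cc4)sc3n2)c1` holds the lowest of the two numbers so far in a functional assay on CCRF-CEM cells (Homo sapiens) for inhibition, read by cell counting, with a stated time of 3 days (a higher number here means a weaker inhibitor, a lower number a stronger inhibitor), where compound 3 gives 3400 nM. Compound 1 `Nc1cccc(-c2cn3nc(-c4cccs4)sc3n2)c1` gives only a limit there, > 250000 nM, which is the limit of > 250000 nM in this assay, at which 1 of the 3 values shown sits. For the measured compounds named here, compound 2 `CCc1ccc(-c2nn3cc(-c4cccc(N)c4)nc3s2)cc1` gives 22000 nM, and the sole measured step, a 6.5-fold lower number from compound 2 to compound 3 (0.81 log units; beyond the scatter), comes from the (1-bromoethenyl)carbonyl entering on the nitrogen. Going by the values given here, compound 4 `C=C(Br)C(=O)Nc1cccc(-c2cn3nc(-c4ccccc4)sc3n2)c1` keeps that group and differs from compound 3 only by hydrogen in place of ethyl on an aromatic carbon, a change at the six-membered carbon ring that no measured step addresses. With nothing to anchor the step, compound 4 is expected to give 7000 nM, with a range from 2500 nM to 25000 nM. The estimated step is a 2.1-fold higher number from compound 3 to compound 4 (0.31 log units; beyond the scatter), a slight weakening that may not exceed the scatter.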

Compound 4, half-maximal inhibitory concentration: 960 nM
Compound 4: middle estimate off by 7.3-fold (0.86 log units), on the high side; measured number outside the range, below it.
By their numbers in this assay, from the lowest: compound 4; then compound 3; then compound 2. At a limit, above all of these: compound 1.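

In this assay, with the (1-bromoethenyl)carbonyl held in place, the change from 4-ethylphenyl to phenyl gives a 3.5-fold lower number from compound 3 to compound 4 (0.55 log units; beyond the scatter). Among the compounds shown here, the ethyl is therefore not required at this position on the six-membered aromatic ring, and the position responds to substitution, which the earlier compounds did not show. Still open, as far as these compounds go, is whether the same change holds on the free amine without the (1-bromoethenyl)carbonyl, and how a methoxy group, a chlorine or a longer chain would compare with hydrogen there. Nothing measured in this series accounts for the step.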